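Swapping a hydroxy for a methoxy on a short amino chain

The source may report more compounds than this note shows. Statements on the series, on what has been measured and on what is new or still open speak of the compounds shown alone.

Measured so far:
compound 1, `CCCNc1[nH]c(C)nc2nccc1-2`: 339000000 nM
compound 2, `Cc1nc2nccc-2c(NCC(C)O)[nH]1`: 30200000 nM

In a functional assay on the whole organism for inhibition, with Nicotiana tabacum as the target (on this read-out lower numbers stand for stronger inhibition and higher numbers for weaker inhibition), compound 2 stands lowest of the two numbers; its nearest neighbour is compound 1, with a gap that exceeds the scatter, as seen in an 11-fold lower number from compound 1 to compound 2 (1.05 log units; beyond the scatter). Compound 3, `COCCNc1[nH]c(C)nc2nccc1-2`, differs from compound 2 by methoxymethyl in place of 1-hydroxyethyl on a saturated chain carbon bound to a nitrogen on an aromatic ring. Among the measured compounds shown here, the one measured step that bears on this is an 11-fold lower number from compound 1 to compound 2 (1.05 log units; beyond the scatter), where the hydroxy entered; here that hydroxy leaves again and a methoxymethyl enters, so compound 3 lies between compound 1 and compound 2 in form. A step back towards compound 1 in this assay is expected, a 4.0-fold higher number from compound 2 to compound 3 (0.60 log units; beyond the scatter). Compound 3 is therefore estimated at 120000000 nM, with a range from 30000000 nM to 450000000 nM.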

Compound 3, half-maximal inhibitory concentration: 166000000 nM
Compound 3: middle estimate off by 1.4-fold (0.14 log units), on the low side; the measured number falls inside the stated range.
By their numbers in this assay, from the lowest: compound 2; then compound 3; then compound 1.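

In this assay, replacing 2-hydroxypropyl with 2-methoxyethyl removes the hydrogen-bond donor while keeping the same atoms, and the number rises (a 5.5-fold higher number from compound 2 to compound 3 (0.74 log units; beyond the scatter)), so these two chains are not interchangeable here. A chain oxygen without that donor still gives a lower number than the all-carbon propyl chain (a 2.0-fold lower number from compound 1 to compound 3 (0.31 log units; beyond the scatter)). Nothing available explains either step.

The change also moves a carbon, so the role of the free hydroxy remains unseparated from that of the chain's shape. As far as these compounds go, how a 2-hydroxyethyl chain or an amine at this place would read remains open.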